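Methylamino on the pyrimidine of a cyclopropyl-benzimidazole series

This account rests on a few compounds, and the source may have more. Where it says the series, first, only, none or still open, it means among the compounds named here.

Measured so far:
compound 1 `Fc1ccc2nc(-c3cncnc3)n(C3CC3)c2c1` — 40 nM
compound 2 `Fc1cc2nc(-c3cncnc3)n(C3CC3)c2cc1F` — 22 nM

Both compounds were run in an assay on cells for inhibition of cytochrome P450 11B2, mitochondrial (Homo sapiens), read by HPLC, with a stated time of 90 min; on this read-out higher numbers stand for weaker inhibition and lower numbers for stronger inhibition. Compound 2 `Fc1cc2nc(-c3cncnc3)n(C3CC3)c2cc1F` gives the lowest of the two numbers, but its nearest neighbour, compound 1 `Fc1ccc2nc(-c3cncnc3)n(C3CC3)c2c1`, sits within the scatter: the step of a 1.8-fold lower number from compound 1 to compound 2 (0.26 log units; within the scatter) does not separate them, so neither can be called the more potent.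

Compound 3 `CNc1ncncc1-c1nc2cc(F)c(F)cc2n1C1CC1` differs from compound 2 in one place: methylamino in place of hydrogen on an aromatic carbon. Among the compounds with values here, the only measured step, a 1.8-fold lower number from compound 1 to compound 2 (0.26 log units; within the scatter), concerns a different group at a different place and was itself within the scatter, so nothing measured speaks directly to a methylamino group entering here. The expectation therefore rests on the absence of evidence for a large effect from the single substitution seen so far, and the step of a 1.4-fold higher number from compound 2 to compound 3 (0.13 log units; within the scatter) is estimated to stay within the scatter. For compound 3 in this assay the estimate is 30 nM, with a range from 8 nM to 120 nM.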

Compound 3, half-maximal inhibitory concentration: < 2 nM
Compound 3: only a limit was reported (the forecaster's own chance of this, stated with the estimate: 3%); middle value at least 15-fold (1.17 log units) from the limit.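

In this assay, within the data shown here, methylamino in place of hydrogen on an aromatic carbon of the six-membered aromatic ring with 2 nitrogen gives an at least 11-fold lower number from compound 2 to compound 3 (1.04 log units; beyond the scatter), the first step that lies beyond the scatter. The only earlier step, a 1.8-fold lower number from compound 1 to compound 2 (0.26 log units; within the scatter), changed a different place and did not separate its two compounds, so this carbon, next to the ring nitrogen and ortho to a large group, is the first place in the series shown to respond strongly to a substitution. The value of compound 3, < 2 nM, is a limit and not a number, and the step inherits that limit, so its full size cannot be read: the limit of < 2 nM in this assay, at which 1 of the 3 values shown sits.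

The compounds shown leave open what a plain amine, a dimethylamino group, a methoxy group or a longer alkylamino chain would do on this same carbon, and so whether the step needs the methylamino group as such. Also open, on these data alone, is whether methylamino gives a step of this size on the core of compound 1, which carries one fluoro rather than two.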